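Replacing the (phenylsulfonyl)amino group with a five-membered ring

The compounds below may be only part of what the source reports. "The series", "measured", "known", "first", "only" and "open" are said of these compounds alone.

Compound 1 `CCCCCNC(=O)NCCCC/C=C\CCCCCNS(=O)(=O)c1ccccc1` gives 3400 nM in a functional assay on Coronary artery (Bos taurus) (a higher number here means that more compound is needed for the effect, a lower number that less compound is needed), and has the highest number of the three compounds measured there. Compound 2 `CCCCCNC(=O)NCCCC/C=C\CCCCCCCc1nnn[nH]1` gives 1100 nM with a 2-(1H-tetrazol-5-yl)ethyl group at that place on the chain. Within the data shown here, compound 3 `CCCCCCC(=O)N(CCCC/C=C\CCCCCCC1=NOS(=O)N1)C(C)C` gives 320 nM but is joined to compound 1 by no single-place step, so it offers only loose guidance. Compound 4 `CCCCCNC(=O)NCCCC/C=C\CCCCCCc1nsc(=O)[nH]1` has not yet been measured, and its structure differs from that of compound 1 by a group of 7 heavy atoms (3 carbon, 2 nitrogen, 1 oxygen, 1 sulfur; one five-membered aromatic ring with 3 hetero atoms) in place of a group of 10 heavy atoms (6 carbon, 1 nitrogen, 2 oxygen, 1 sulfur; one six-membered aromatic ring of carbon only), on a saturated chain carbon, five bonds along the chain from a double-bonded chain carbon in the shared core. Among the measured compounds shown here, the only measured step that bears on this change is a 3.1-fold lower number from compound 1 to compound 2 (0.49 log units; beyond the scatter) and it also removes the (phenylsulfonyl)amino group. The new ring itself has not been tested, so the transfer is uncertain. A modest step of similar size toward a lower number is therefore expected in this assay for compound 4. For compound 4 the estimate is 1000 nM with an expected range from 300 nM to 3500 nM in this assay. That estimate corresponds to a 3.4-fold lower number from compound 1 to compound 4 (0.53 log units; beyond the scatter) as the expected change.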

Compound 4, half-maximal effective concentration: 2400 nM
Beside the measured number, compound 4's estimate is 2.4-fold (0.38 log units) below it; the measured number falls inside the stated range.
By their numbers in this assay, from the lowest: compound 3; then compound 2; then compounds 4 and 1 (each within the scatter of the next).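

In this assay, putting the new five-membered ring in place of (phenylsulfonyl)amino, on a saturated chain carbon, five bonds along the chain from a double-bonded chain carbon, gives a 1.4-fold lower number from compound 1 to compound 4 (0.15 log units; within the scatter), so this exchange leaves the two compounds within the scatter of each other. Losing the (phenylsulfonyl)amino group is therefore not enough on its own to reach the number of compound 2, since exchanging the tetrazole ring for the new ring gives a 2.2-fold higher number from compound 2 to compound 4 (0.34 log units; beyond the scatter) and the choice of ring does count at this place. Nothing at hand accounts for this difference between the two rings.

The compounds shown leave open whether a carboxylic acid at this place would track the tetrazole ring or the new ring. They also leave open whether a longer chain carrying the new ring would change its number.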